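Carbamoyl for chloro on the aryl group of compound 2

The compounds below may be only part of what the source reports. "The series", "measured", "known", "first", "only" and "open" are said of these compounds alone.

Measured compounds:
- compound 1 `CC(C)NCc1ccc(-c2c3ncn(CC4(O)CCN(Cc5ccc(-c6ccco6)cc5Cl)CC4)c(=O)c3nn2C)cc1` gives 29.1 nM in an assay on isolated protein for inhibition of ubiquitin carboxyl-terminal hydrolase 7 (Homo sapiens), with stated times of 30 min and 2 h; a higher number here means a weaker inhibitor, a lower number a stronger inhibitor
- compound 2 `Cn1nc2c(=O)n(CC3(O)CCN(Cc4ccc(-c5ccco5)cc4Cl)CC3)cnc2c1-c1ccc(Cl)cc1` gives 143 nM in this assay

Compound 2 stands at the higher of the two numbers shown in this assay; its only neighbour is compound 1, and the step of a 4.9-fold higher number from compound 1 to compound 2 (0.69 log units; beyond the scatter) is beyond the scatter. Compound 3 `Cn1nc2c(=O)n(CC3(O)CCN(Cc4ccc(-c5ccco5)cc4Cl)CC3)cnc2c1-c1ccc(C(N)=O)cc1` has not been measured. It differs from compound 2 by carbamoyl in place of chloro on an aromatic carbon.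

For the measured compounds named here, only one measured step bears on this change: a 4.9-fold higher number from compound 1 to compound 2 (0.69 log units; beyond the scatter), which shows that the compound with the larger group on this aromatic carbon gave the lower number, and that the chloro analogue, compound 2, was weaker. Going by the values given here, compound 3 again carries a larger group at that carbon, one with one hydrogen-bond donor and one hydrogen-bond acceptor, so a step back toward a lower number is expected, though of smaller size than the measured step, since the entering group is not the one in compound 1. Compound 3 is therefore expected at 60 nM, in the range 20 nM to 180 nM, corresponding to an expected step of a 2.4-fold lower number from compound 2 to compound 3 (0.38 log units; beyond the scatter).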

Compound 3, half-maximal inhibitory concentration: 80.8 nM
Compound 3: the middle estimate sits 1.3-fold (0.13 log units) below what was measured; measured number inside the range.
By their numbers in this assay, from the lowest: compound 1; then compounds 3 and 2 (each within the scatter of the next).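

In this assay, the carbamoyl and chloro groups, on an aromatic carbon para to a large group, cannot be told apart: the change gives a 1.8-fold lower number from compound 2 to compound 3 (0.25 log units; within the scatter), so the larger group with a hydrogen-bond donor and acceptor does not separate compound 3 from the chloro analogue. The (isopropylamino)methyl group keeps its distinct result, with a 2.8-fold higher number from compound 1 to compound 3 (0.44 log units; beyond the scatter), which shows that exchanging it for carbamoyl on the same shared core does not retain the number of compound 1, and that size at this carbon alone does not account for the earlier step. No measurement here gives a reason for either result.

The compounds shown leave open which part of the (isopropylamino)methyl group carries its effect, as a simple aminomethyl group, a dimethylaminomethyl group and a longer aminoethyl chain do not appear among them. They also leave open how a carboxylic acid or a methyl ester at this carbon would compare with the carbamoyl group of compound 3.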